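Clearance notes on the shared core, compound 2 to compound 4

The compounds below may be only part of what the source reports. "The series", "measured", "known", "first", "only" and "open" are said of these compounds alone.

Three compounds of the shared core have been run in an in vivo ADME assay on the whole organism (strain Sprague-Dawley) for pharmacokinetics, with Rattus norvegicus as the target, at a dose of 5 mg/kg by the intravenous route; on this read-out higher numbers stand for fast clearance and lower numbers for slow clearance. Compound 1 `Cc1cccc(C)c1CN[C@]1(CCC(C)(C)C)C(=O)C(C2=NS(=O)(=O)c3cc(NS(C)(=O)=O)ccc3N2)=C(O)c2ccccc21` gives 11.7 mL/min/kg. Compound 2 `CC(C)CC[C@@]1(NCc2ccccc2)C(=O)C(C2=NS(=O)(=O)c3cc(NS(C)(=O)=O)ccc3N2)=C(O)c2ccccc21` gives 19.3 mL/min/kg. Compound 3 `Cc1cccc(CNC2(CCC(C)(C)C)C(=O)C(C3=NS(=O)(=O)c4cc(NS(C)(=O)=O)ccc4N3)=C(O)c3ccccc32)n1` gives 28.3 mL/min/kg. Compound 2 stands second highest of the three numbers; its nearest neighbour is compound 3 and its furthest is compound 1, and both gaps lie within the usual scatter, so no order among these three is claimed.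

Compound 4 `CC(C)CC[C@@]1(NS(C)(=O)=O)C(=O)C(C2=NS(=O)(=O)c3cc(NS(C)(=O)=O)ccc3N2)=C(O)c2ccccc21` is not yet measured in this assay. Against compound 2 the change is methylsulfonyl in place of benzyl on an amine nitrogen. Going by the values given here, no measured pair shows this change, so its effect on clearance is unknown here. For compound 4 the expected outcome is a step of a 1.2-fold lower number from compound 2 to compound 4 (0.08 log units; within the scatter), not beyond the scatter in either direction. The estimate for compound 4 is 16 mL/min/kg, with a range from 8 mL/min/kg to 32 mL/min/kg.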

Compound 4, clearance: 71.7 mL/min/kg
Estimate against measurement, compound 4: 4.5-fold (0.65 log units) below; the whole stated range lies below it.
By their numbers in this assay, from the lowest: compounds 1, 2 and 3 (each within the scatter of the next, the first and the last beyond it); then compound 4.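

In this assay, methylsulfonyl in place of benzyl on an amine nitrogen whose other neighbour is a saturated ring carbon gives a 3.7-fold higher number from compound 2 to compound 4 (0.57 log units; beyond the scatter). Going by these compounds alone, this is the only single-place step so far, and it shows that the group on this nitrogen can move clearance beyond the scatter. Nothing at hand explains the step.

One pair cannot separate the departure of benzyl from the arrival of methylsulfonyl. On these data alone, how an acetyl or a plain methyl on the same nitrogen would read remains open.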